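Swapping the indole for a cinnamoyl group

The source may report more compounds than this note shows. Statements on the series, on what has been measured and on what is new or still open speak of the compounds shown alone.

Three compounds share one core, a long carbon chain joined through an amide to a threonine-like unit that carries a second amide. They differ only in the ring attached to that second carbonyl carbon. Compound 1 `CCCCCCCCCCCCCCNC(=O)[C@@H](NC(=O)c1ccco1)[C@@H](C)O` bears a furan-2-yl group and, in a functional assay on SW-620 cells (Homo sapiens) for cytotoxicity, read by MTT assay, with a stated time of 48 h (a lower number here means a stronger inhibitor, a higher number a weaker inhibitor), compound 1 gives 200000 nM. Compound 2 `CCCCCCCCCCCCCCNC(=O)[C@@H](NC(=O)c1cc2ccccc2o1)[C@@H](C)O` carries a 1-benzofuran-2-yl group and in this assay compound 2 gives 26700 nM. Compound 3 `CCCCCCCCCCCCCCNC(=O)[C@@H](NC(=O)c1cc2ccccc2[nH]1)[C@@H](C)O` carries a 1H-indol-2-yl group and in this assay compound 3 gives 15200 nM.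

Compound 3 has the lowest number of the three: the larger gap is a 13-fold lower number from compound 1 to compound 3 (1.12 log units; beyond the scatter), while the difference between compound 2 and compound 3 is a 1.8-fold lower number from compound 2 to compound 3 (0.24 log units; within the scatter), so these two cannot be ranked against each other. The step of a 7.5-fold lower number from compound 1 to compound 2 (0.87 log units; beyond the scatter) likewise points the same way as the enlargement of the ring system.

Compound 4 `CCCCCCCCCCCCCCNC(=O)[C@@H](NC(=O)/C=C/c1ccccc1)[C@@H](C)O` is made from compound 3 by the change (2-phenylethenyl in place of 1H-indol-2-yl on a carbonyl carbon). Going by the values given here, none of the measured steps covers this change; the earlier steps only show that leaving the small furan ring helped. Because the step of a 13-fold lower number from compound 1 to compound 3 (1.12 log units; beyond the scatter) is the largest seen, losing the indole is expected to cost something, giving an estimated 2.3-fold higher number from compound 3 to compound 4 (0.36 log units; beyond the scatter) in this assay. For compound 4 the expected value is 35000 nM, within a range from 8000 nM to 150000 nM.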

Compound 4, half-maximal inhibitory concentration: 200000 nM
Compound 4: the middle estimate sits 5.7-fold (0.76 log units) below what was measured, and the stated range ends below it.
By their numbers in this assay, from the lowest: compounds 3 and 2 (each within the scatter of the next); then compounds 1 and 4 (each within the scatter of the next).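

In this assay, the gain from moving away from furan-2-yl does not carry over to every larger group on this carbonyl carbon. Putting 2-phenylethenyl in place of 1H-indol-2-yl raises the number (a 13-fold higher number from compound 3 to compound 4 (1.12 log units; beyond the scatter)), and putting it in place of 1-benzofuran-2-yl does the same (a 7.5-fold higher number from compound 2 to compound 4 (0.87 log units; beyond the scatter)), while compound 4 stands level with the furan compound (no change at the digits printed from compound 1 to compound 4 (within the scatter)). So leaving the furan ring is not enough in itself, and a group with almost as many heavy atoms as 1H-indol-2-yl can lose the whole gain, which makes the identity of the group at this position matter, not just its size. Nothing measured here explains why these groups behave so differently.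

The compounds shown leave open whether the double bond or the missing five-membered ring accounts for the loss, a question that a phenyl group or a 2-phenylethyl group on the same carbonyl carbon would help to settle. Also open, from the compounds shown here alone, is whether an amine or a carboxylic acid on the 1H-indol-2-yl ring would lower the number any further.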